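The source may hold more compounds than are shown below. What is called first, only, known or untested is meant among the compounds shown, and "the series" means these compounds.

Compound 1 `Cc1ccc(N(C)S(=O)(=O)C2CC3OC2C(c2ccc(NC(=O)CCCCCCC(=O)O)cc2)=C3c2ccc(O)cc2)cc1`: 23200 nM
Compound 2 `Cc1cccc(N(C)S(=O)(=O)C2CC3OC2C(c2ccc(NC(=O)CCCCCCC(=O)O)cc2)=C3c2ccc(O)cc2)c1`: 30200 nM

In a functional assay on MCF7 cells (Homo sapiens) for antiproliferative activity, read by MTT assay, with a stated time of 72 h (on this read-out lower numbers stand for stronger inhibition and higher numbers for weaker inhibition), compound 2 gives 30200 nM, which lies within the usual scatter of compound 1. Compound 3 `COc1cccc(N(C)S(=O)(=O)C2CC3OC2C(c2ccc(NC(=O)CCCCCCC(=O)O)cc2)=C3c2ccc(O)cc2)c1` differs from compound 2 by one change, methoxy in place of methyl on an aromatic carbon, meta to a large group. For the measured compounds named here, the only measured step, a 1.3-fold higher number from compound 1 to compound 2 (0.11 log units; within the scatter), moved the methyl group around its ring and did not swap it for another group. It is therefore a weak guide, and no shift beyond the scatter is expected. The estimated step, a 1.1-fold lower number from compound 2 to compound 3 (0.05 log units; within the scatter), is expected to stay within the scatter. For compound 3 the expected value is 27000 nM, with an estimated range of 13000 nM to 55000 nM.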

Compound 3, half-maximal inhibitory concentration: 39400 nM
Beside the measured number, compound 3's estimate is 1.5-fold (0.16 log units) below it; the measured number falls inside the stated range.
By their numbers in this assay, from the lowest: compounds 1, 2 and 3 (each within the scatter of the next).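

In this assay, for the compounds shown here, methoxy in place of methyl on this ring gives a 1.3-fold higher number from compound 2 to compound 3 (0.12 log units; within the scatter) and is the first exchange of one group for another at this position. The exchange adds one hydrogen-bond acceptor, yet the two numbers stay within the scatter, and the step with 3-methoxyphenyl in place of 4-methylphenyl gives a 1.7-fold higher number from compound 1 to compound 3 (0.23 log units; within the scatter). No measurement here bears on the reason for these results. Going by these compounds, whether an amine or a carboxylic acid at this position would move the number beyond the scatter remains open.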